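Adding an isopropyl group to the ring of a cinnamate ester

The source may hold more compounds than are shown below. What is called first, only, known or untested is meant among the compounds shown, and "the series" means these compounds.

In a functional assay on the whole organism for inhibition, with Brassica rapa subsp. chinensis as the target, with a stated time of 3 days, tested at 100 ppm (on this read-out higher numbers stand for more inhibition of growth at the one concentration tested and lower numbers for less inhibition of growth), compound 1 `CC(C)OC(=O)/C=C/c1ccccc1` gives 2%, the lowest of the three numbers recorded. Compound 2 `CCC(C)OC(=O)/C=C/c1ccccc1`, which carries a methyl in place of hydrogen on a saturated chain carbon, two bonds along the chain from an oxygen next to a carbonyl group, gives 20%, so that a number 18 percentage points higher from compound 1 to compound 2 (beyond the scatter). Compound 3 `CC(C)NC(=O)/C=C/c1ccccc1`, with isopropylamino in place of isopropoxy on the carbonyl carbon, gives 76%, and a number 74 percentage points higher from compound 1 to compound 3 (beyond the scatter).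

Compound 4 `CC(C)OC(=O)/C=C/c1ccc(C(C)C)cc1` differs from compound 1 at the other end of the molecule: isopropyl in place of hydrogen on an aromatic carbon, on an aromatic carbon of a six-membered aromatic ring of carbon only, para to a group of 8 heavy atoms. Within the data shown here, none of the measured steps touches the ring, so no step speaks directly to this change. Among the measured compounds shown here, the only change that, like this one, adds carbon without altering the ester is the one from compound 1 to compound 2, which was modest. For compound 4 a small rise in this assay is therefore expected, a number 10 percentage points higher from compound 1 to compound 4 (within the scatter), with wide uncertainty, giving an estimated value of 12% within a range from 0% to 40%.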

Compound 4, percent growth inhibition at one concentration: 0%
The estimate for compound 4 lay 12 percentage points above the measured number, within the range that was stated.
By their numbers in this assay, from the lowest: compounds 4 and 1 (each within the scatter of the next); then compound 2; then compound 3.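

In this assay, isopropyl in place of hydrogen on an aromatic carbon gives a number 2 percentage points lower from compound 1 to compound 4 (within the scatter), so this first measured change on the ring brings no step beyond the scatter, unlike the change at the carbonyl carbon, a number 74 percentage points higher from compound 1 to compound 3 (beyond the scatter). Compound 1 already gives 2%, close to the bottom of this read-out, so the pair shows that isopropyl at this place does not lift the ester to a clear level of growth inhibition, but it cannot show whether the group would lower a higher number. No measurement shown here offers an explanation for this result.

The compounds shown leave open what the same isopropyl would do on compound 3, which gives 76% and so has room on the scale for a fall as well as a rise. They also leave open whether a different group at this place, such as a chlorine, a methoxy or a carboxylic acid, would give a number beyond the scatter from that of compound 1.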